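The source may hold more compounds than are shown below. What is called first, only, known or untested is meant among the compounds shown, and "the series" means these compounds.

Measured so far in an assay on SH-EP1 cells for agonist activity at Neuronal acetylcholine receptor; alpha4/beta2 (Homo sapiens), read by FLIPR and calcium flux; a higher number here means that more compound is needed for the effect, a lower number that less compound is needed:
compound 1 `CC(=O)N1CC2CC(C1)N2` — 5100 nM
compound 2 `CC(C)C(=O)N1CC2CC(C1)N2` — 19000 nM
compound 3 `O=C(C1CCCC1)N1CC2CC(C1)N2` — 11000 nM

Compound 2 gives the highest of the three numbers in this assay; compound 3 sits within the scatter of it, while compound 1 lies a clearly lower number away. Compound 4 `O=C([C@H]1C[C@H]1F)N1CC2CC(C1)N2` differs from compound 2 by 2-fluorocyclopropyl in place of isopropyl on a carbonyl carbon. Among the measured compounds shown here, the one measured step that bears on an exchange at this carbonyl carbon is a 3.7-fold higher number from compound 1 to compound 2 (0.57 log units; beyond the scatter), where a larger group gave a higher number; the cyclopentyl of compound 3 also gave a number above compound 1. For the measured compounds named here, the fluorinated three-membered ring has no measured counterpart here, so the direction is uncertain. Compound 4 is expected to land near compound 2, with a step of a 1.6-fold lower number from compound 2 to compound 4 (0.20 log units; within the scatter) that is not clearly beyond the scatter. Estimated value for compound 4 in this assay: 12000 nM (range 4000 nM to 35000 nM).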

Compound 4, half-maximal effective concentration: 210 nM
Estimate against measurement, compound 4: 57-fold (1.76 log units) above, outside the stated range (below it).
By their numbers in this assay, from the lowest: compound 4; then compound 1; then compounds 3 and 2 (each within the scatter of the next).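

In this assay, a larger group on the carbonyl carbon no longer goes with a higher number: 2-fluorocyclopropyl gives a 90-fold lower number from compound 2 to compound 4 (1.96 log units; beyond the scatter), and compound 4 goes against the trend suggested by compound 1 and compound 2. The same exchange also gives a 24-fold lower number from compound 1 to compound 4 (1.39 log units; beyond the scatter), so this position can move the number far below the level of the simple acyl groups.

On these data alone, whether the three-membered ring, the fluorine or the defined stereochemistry carries the step stays open; plain cyclopropyl and the opposite stereoisomer of 2-fluorocyclopropyl would separate these. No supporting measurement explains the result.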